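A few compounds are considered here, and "the series" means these few. Any claim that something is new, unique, unknown or untested is made for them only; others in the source may bear on it.

Compound 1 `CC1CCc2ccccc2N1S(=O)(=O)c1ccc(F)cc1` is the reference point here. For the measured compounds named here, in an ADME assay on L6 cells (Rattus norvegicus) for cytotoxicity (a lower number here means a stronger inhibitor, a higher number a weaker inhibitor), compound 1 gives 67600 nM, which is the highest of the two numbers measured so far. Going by the values given here, the only other compound with a number is compound 2 `COc1ccc(S(=O)(=O)N2c3ccccc3CCC2C)cc1`, which in this assay gives 5990 nM. Among the compounds with values here, the one known step, methoxy in place of fluoro on an aromatic carbon, runs an 11-fold lower number from compound 1 to compound 2 (1.05 log units; beyond the scatter), so a change at this position can move the number a long way.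

Compound 3 `CC1CCc2ccccc2N1S(=O)(=O)c1ccc(Cl)cc1` has not yet been measured. It differs from compound 1 as follows: chloro in place of fluoro on an aromatic carbon. Within the data shown here, the same position is touched as in the step from compound 1 to compound 2, but the group that enters is chloro rather than methoxy, and no measured pair shows what chloro does here. Among the measured compounds shown here, the one bearing step therefore sets an upper limit on how large a move is plausible, not its direction or size for chloro. The expectation for compound 3 is a modest lowering, a 2.3-fold lower number from compound 1 to compound 3 (0.35 log units; beyond the scatter), with the estimate for compound 3 in this assay at 30000 nM, between 10000 nM and 80000 nM.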

Compound 3, half-maximal inhibitory concentration: 20500 nM
Beside the measured number, compound 3's estimate is 1.5-fold (0.17 log units) above it, and the stated range covers the measured number.
By their numbers in this assay, from the lowest: compound 2; then compound 3; then compound 1.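

Replacing fluoro with another single atom is enough to change the result in this assay: chloro in place of fluoro gives a 3.3-fold lower number from compound 1 to compound 3 (0.52 log units; beyond the scatter), so a drop at this position does not depend on methoxy alone. Chloro does not go as far as methoxy, as chloro in place of methoxy gives a 3.4-fold higher number from compound 2 to compound 3 (0.53 log units; beyond the scatter), and the three groups on this aromatic carbon now rank methoxy, chloro, fluoro from the lowest number to the highest. No measurement in hand explains why the number follows this order.

With only three groups shown at this position, it remains open where an amine, a carboxylic acid or a longer chain such as ethoxy would fall in that ranking. As far as these compounds go, it is also open whether the same ranking would hold if the rest of the molecule were changed, as all three compounds share the core of compound 1.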